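Expected tolerance of compound 4 in a cytotoxicity assay

The source may hold more compounds than are shown below. What is called first, only, known or untested is meant among the compounds shown, and "the series" means these compounds.

Values in an ADME assay on HOS cells (Homo sapiens) for cytotoxicity; a lower number here means that less compound is tolerated, a higher number that more compound is tolerated:
- compound 1 `CN(Cc1nc2ccccc2n1CCCCN)C1CCCc2cccnc21`: 2900 nM
- compound 2 `CN(Cc1nc2ccccc2n1CCCNC(=O)C(F)(F)F)C1CCCc2cccnc21`: 10400 nM
- compound 3 `CN(Cc1nc2cccc(CN)c2[nH]1)C1CCCc2cccnc21`: > 20000 nM

Compound 3 gives > 20000 nM, which is a limit of this assay and not a number. As far as these compounds go, this is the limit of > 20000 nM in this assay, at which 1 of the 3 values shown sits, so the true position of compound 3 remains open.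

Compound 4 `CN(Cc1nc2cccc(N3CCNCC3)c2[nH]1)C1CCCc2cccnc21` keeps the shared core but carries piperazin-1-yl in place of aminomethyl on an aromatic carbon. Going by the values given here, no measured step covers this change at this place. Among the compounds with values here, the only measured step, a 3.6-fold higher number from compound 1 to compound 2 (0.55 log units; beyond the scatter), has ((trifluoromethyl)carbonyl)amino in place of aminomethyl on a saturated chain carbon, so it bears on the change only loosely. It does show that a modest step can follow when an aminomethyl group is replaced. The measured numbers, from compound 1 at 2900 nM to compound 2 at 10400 nM, inform the plausible range. A modest step of similar size is therefore expected, towards a lower number, though the direction is uncertain.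

The expected change is an at least 1.5-fold lower number from compound 3 to compound 4 (0.18 log units; that floor lies within the scatter).

For compound 4 the estimated value is 13000 nM, with an expected range of 5000 nM to 30000 nM.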

Compound 4, half-maximal cytotoxic concentration: > 20000 nM
Compound 4 was reported as a limit; the forecaster's own chance of this, stated with the estimate: 35%; at least 1.5-fold (0.18 log units) between middle value and limit.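

In this assay compound 4 gives > 20000 nM as a limit and not a number. Compound 3 also gives > 20000 nM as a limit and not a number. The step from compound 3 to compound 4 therefore cannot be read, since both sit at the same limit: the limit of > 20000 nM in this assay, at which 2 of the 4 values shown sit.

For this assay the compounds shown leave open how far the true value of either compound lies past that limit, and whether piperazin-1-yl and aminomethyl differ at all.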